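The compounds below may be only part of what the source reports. "The series", "measured", "known", "first", "only" and "open" are said of these compounds alone.

Measured compounds:
Compound 1, `Nc1ccccc1NC(=O)c1ccc(NC(=O)NCc2ccc(Cl)nc2)cc1`: 34000 nM
Compound 2, `Nc1ccccc1NC(=O)c1ccc(NC(=S)NCc2cncc(F)c2)cc1`: 85000 nM

Both numbers come from a functional assay on MDA-MB-231 cells (Homo sapiens) for cytotoxicity, read by MTT assay, with a stated time of 72 h; on this read-out higher numbers stand for weaker inhibition and lower numbers for stronger inhibition. In this assay compound 1 gives 34000 nM, and compound 2 gives 85000 nM. Within the data shown here, compound 1 therefore stands at the lowest of the two numbers, and its only neighbour, compound 2, sits at a higher number, a gap that lies beyond the usual scatter of this assay. The two measured compounds differ from each other in more than one place, so no single step between them is computed; only their two values are shown.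

The step under consideration leads from compound 1 to compound 3, `Nc1ccccc1NC(=O)c1ccc(NC(=O)NCc2ccc(F)nc2)cc1`, which has not yet been measured in this assay. The difference is fluoro in place of chloro on an aromatic carbon. Among the measured compounds shown here, the measured pair holds no step that isolates this exchange, so the expectation rests on the change being small, without a clear direction, and most likely within the scatter. Compound 3 is expected to give 45000 nM, with a range from 18000 nM to 110000 nM. This estimate means an expected step of a 1.3-fold higher number from compound 1 to compound 3 (0.12 log units; within the scatter), which is expected to stay within the scatter.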

Compound 3, half-maximal inhibitory concentration: 91000 nM
Compound 3: middle estimate off by 2.0-fold (0.31 log units), on the low side; the range from low to high includes it.
By their numbers in this assay, from the lowest: compound 1; then compounds 2 and 3 (each within the scatter of the next).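

In this assay, among these compounds, the change from 6-chloropyridin-3-yl to 6-fluoropyridin-3-yl gives a 2.7-fold higher number from compound 1 to compound 3 (0.43 log units; beyond the scatter) and so provides the first single-place comparison in this small set. Among the compounds shown here, the step is modest, but it shows that this aromatic carbon, next to the ring nitrogen and para to a large group, is not indifferent to which of these two halogens it carries, even though only one heavy atom changes and the counted hydrogen-bond donors, acceptors and net charge stay the same. In this one pair, chloro goes with the stronger inhibition, and no measurement offered here accounts for the difference.

The compounds shown leave open whether a methoxy group, an amine, a trifluoromethyl group or plain hydrogen at this position would fall on the side of chloro or of fluoro, or beyond either. For the compounds shown here, they also hold no pair showing whether the same exchange would give a similar step elsewhere on the ring or with the sulfur-containing linker of compound 2, so this single step cannot yet be called a trend.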